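The source may hold more compounds than are shown below. What is called first, only, known or untested is meant among the compounds shown, and "the series" means these compounds.

Compound 1, with the structure `O=C(N/N=C/c1ccc(F)cc1Cl)Nc1cc2c(Nc3ccc(F)c(Cl)c3)ncnc2cc1O[C@H]1CCOC1`, is the starting point of this comparison. In a functional assay on HepG2 cells (Homo sapiens) for cytotoxicity, read by MTT assay, with a stated time of 72 h (on this read-out higher numbers stand for weaker inhibition and lower numbers for stronger inhibition), compound 1 gives 26100 nM. Compound 3, with the structure `COc1cc2ncnc(Nc3ccc(F)c(Cl)c3)c2cc1NC(=O)N/N=C/c1ccc(F)cc1Cl`, differs from compound 1 in one place: methyl in place of oxolan-3-yl on an oxygen on an aromatic ring. In this assay compound 3 gives 29200 nM, so that the step of a 1.1-fold higher number from compound 1 to compound 3 (0.05 log units; within the scatter) is a small one.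

Compound 2, with the structure `CC(C)(C)c1cc(/C=N/NC(=O)Nc2cc3c(Nc4ccc(F)c(Cl)c4)ncnc3cc2O[C@H]2CCOC2)cc(C(C)(C)C)c1O`, carries a different group on the other side of the molecule; the difference between its core and the core of compound 1 is not broken down here. In this assay compound 2 gives 12500 nM, the lowest of the three numbers, which on this read-out means the strongest inhibition among them.

Compound 4, with the structure `COc1cc2ncnc(Nc3ccc(F)c(Cl)c3)c2cc1NC(=O)N/N=C/c1cc(C(C)(C)C)c(O)c(C(C)(C)C)c1`, has not yet been measured. It differs from compound 2 in one place: methyl in place of oxolan-3-yl on an oxygen on an aromatic ring. This is the same change that was made from compound 1 to compound 3, and it sits at the same kind of place, described in the same words. Because the earlier step of a 1.1-fold higher number from compound 1 to compound 3 (0.05 log units; within the scatter) stayed within the scatter, the step from compound 2 to compound 4 is expected to be similarly small, namely a 1.1-fold higher number from compound 2 to compound 4 (0.03 log units; within the scatter). For compound 4 the estimate in this assay is therefore 13500 nM, expected to fall between 6000 nM and 30000 nM.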

Compound 4, half-maximal inhibitory concentration: 26800 nM
The estimate for compound 4 lay 2.0-fold (0.30 log units) below the measured number, and the stated range covers the measured number.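

Replacing oxolan-3-yl with methyl on the oxygen of compound 2 weakens inhibition in this assay by a modest amount: a 2.1-fold higher number from compound 2 to compound 4 (0.33 log units; beyond the scatter). Taken alone, this step lies beyond the usual scatter, whereas the same change on the core of compound 1 did not, yet the two steps do not differ by more than repeated measurements could explain: the same change on two cores in this assay, a 1.1-fold higher number (0.05 log units; within the scatter) from compound 1 to compound 3 and a 2.1-fold higher number (0.33 log units; beyond the scatter) from compound 2 to compound 4, 1.9-fold (0.28 log units) apart, within the scatter of two such steps

This agreement shows that these two pairs give no firm evidence that the core alters the effect of the change, but it does not show that the effect is the same on both cores. Two pairs are too few to establish a rule for the series.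

On this oxygen the compounds shown carry only methyl and oxolan-3-yl, the latter in a single stereochemical form, leaving open what the mirror-image oxolan-3-yl, an ethyl group or a longer chain ending in an amine would do. Going by these compounds, it also remains open whether the step seen here would hold on a core with a group other than those in these compounds at the far end of the molecule, such as a carboxylic acid.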